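Adding a nitro group to compound 1

The source may report more compounds than this note shows. Statements on the series, on what has been measured and on what is new or still open speak of the compounds shown alone.

Compound 1 (`CCOC(=O)c1cccnc1SNC(=O)Nc1ncccn1`) gives 15000 nM
Compound 2 (`CCOC(=O)c1cccnc1SNC(=O)Nc1nc(OC)cc(OC)n1`) gives 700 nM

In a functional assay on CCRF-CEM cells (Homo sapiens) for cytotoxicity (on this read-out higher numbers stand for weaker inhibition and lower numbers for stronger inhibition), compound 1 stands at 15000 nM and holds the higher of the two numbers, while the lower number belongs to compound 2 at 700 nM. Compound 3 (`CCOC(=O)c1cc([N+](=O)[O-])cnc1SNC(=O)Nc1ncccn1`) has not been measured yet. It keeps the core of compound 1 and takes nitro in place of hydrogen on an aromatic carbon. The new group sits on a six-membered aromatic ring with 1 nitrogen, two atoms from the ring nitrogen, meta to an ethoxycarbonyl group and para to a large group. Among the measured compounds shown here, no measured pair shows this change, so the expectation is uncertain. Compound 1 at 15000 nM is the high end of what has been seen, so a moderate move toward a lower number is expected, perhaps only just beyond the scatter. The estimated change is a 3.0-fold lower number from compound 1 to compound 3 (0.48 log units; beyond the scatter) in this reading. Estimated for compound 3 is 5000 nM with 1000 nM to 25000 nM as the expected range.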

Compound 3, half-maximal inhibitory concentration: 1500 nM
Estimate against measurement, compound 3: 3.3-fold (0.52 log units) above; measured number inside the range.
By their numbers in this assay, from the lowest: compound 2; then compound 3; then compound 1.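

In this assay, putting nitro in place of hydrogen on an aromatic carbon gives a 10-fold lower number from compound 1 to compound 3 (1.00 log units; beyond the scatter), a step beyond the usual scatter. Among the compounds shown here, it is the first information about this position, two atoms from the ring nitrogen, meta to an ethoxycarbonyl group and para to a large group, since compound 1 and compound 2 both carry hydrogen there and so say nothing about it. The step shows that this hydrogen can be replaced by a group of three heavy atoms with the number falling rather than rising, although no measurement in hand accounts for the change.

From the compounds shown here alone, with a single substituent at a single position, it remains open whether the step belongs to nitro in particular or whether an amine, a nitrile or a chlorine atom at the same place would give a step of similar size. Going by these compounds, it also remains open whether the nitro group would lower the number to the same extent in a compound that also carries the two methoxy groups of compound 2.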